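From methyl to bromo in an antiproliferative series

This account rests on a few compounds, and the source may have more. Where it says the series, first, only, none or still open, it means among the compounds named here.

In a functional assay on B16-F10 cells (Mus musculus) for antiproliferative activity, read by MTT assay, with a stated time of 48 h (on this read-out lower numbers stand for stronger inhibition and higher numbers for weaker inhibition), compound 1 `Cc1ccc(-c2cc(NC(=O)/C=C/c3ccc(Cl)cc3)n[nH]2)cc1` gives 1520 nM. Compound 2 `Cc1ccc(-c2cc(NC(=O)/C=C/c3ccc(C(F)(F)F)cc3)n[nH]2)cc1` gives 1210 nM and compound 3 `Cc1ccc(-c2cc(NC(=O)/C=C/c3ccc(F)cc3)n[nH]2)cc1` gives 1430 nM. Compound 1 therefore sits level with both, as all three values lie within the scatter of each other.

The unmeasured compound 4 `O=C(/C=C/c1ccc(Cl)cc1)Nc1cc(-c2ccc(Br)cc2)[nH]n1` keeps the chloro group of compound 1 and alters a different group: bromo in place of methyl on an aromatic carbon. The 4-methylphenyl group of compound 1 thus becomes 4-bromophenyl in compound 4.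

Two measured steps start from compound 1. Trifluoromethyl in place of chloro gave a 1.3-fold lower number from compound 1 to compound 2 (0.10 log units; within the scatter), and fluoro in place of chloro gave a 1.1-fold lower number from compound 1 to compound 3 (0.03 log units; within the scatter). Both stay within the scatter, but both concern the chloro position, so they bear on the new change only indirectly. For the measured compounds named here, no measured compound alters the 4-methylphenyl group, and the data offer no direct guide to this swap.

With nothing pointing either way, no step beyond the scatter is expected in this assay, in either direction. The expected change is a 1.2-fold lower number from compound 1 to compound 4 (0.07 log units; within the scatter). For compound 4 the estimated value is 1300 nM, with an expected range from 600 nM to 2800 nM.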

Compound 4, half-maximal inhibitory concentration: 1080 nM
Beside the measured number, compound 4's estimate is 1.2-fold (0.08 log units) above it; low and high end bracket the measured number.
By their numbers in this assay, from the lowest: compounds 4, 2, 3 and 1 (each within the scatter of the next).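

In this assay, for the compounds shown here, the 4-methylphenyl group can now be read for the first time, since all the earlier steps changed only the chloro position: bromo in place of methyl gave a 1.4-fold lower number from compound 1 to compound 4 (0.15 log units; within the scatter) in this one pair. The step shows that on this aromatic carbon, one heavy atom of carbon can give way to one of bromine without moving the number beyond the usual scatter, so compound 1 and compound 4 count as level. No measurement shown here accounts for this result or tells what methyl and bromo each contribute.

Among the compounds shown, methyl and bromo are the only groups seen in this place, so it stays open whether an amine, a carboxylic acid or a longer chain there would produce a step beyond the scatter. Also open, going by these compounds, is whether bromo in this place would read the same with trifluoromethyl or fluoro in place of chloro, as that would show whether the two sites act independently in this assay.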